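Adding One Methoxy Group to Compound 2

This account rests on a few compounds, and the source may have more. Where it says the series, first, only, none or still open, it means among the compounds named here.

In a functional assay on NCI-H460 cells (Homo sapiens) for cytotoxicity, read by MTT assay, with a stated time of 24 h (on this read-out higher numbers stand for weaker inhibition and lower numbers for stronger inhibition), compound 1 `C#CCn1c(=O)c(C=O)cc2cc(F)ccc21` gives > 100000 nM, a limit of the assay and not a number. Compound 2 `C#CCn1c(=O)c(/C=C/C(=O)/C=C(O)/C=C/c2ccc(O)c(OC)c2)cc2ccccc21` shares its core with compound 1 but carries a much larger side chain and lacks the fluorine. In this assay, for the measured compounds named here, compound 2 gives 25400 nM, the only true number so far, so it stands alone as the single firm reference point.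

Compound 3 `C#CCn1c(=O)c(/C=C/C(=O)/C=C(O)/C=C/c2ccc(O)c(OC)c2)cc2cc(OC)ccc21` is compound 2 with one small edit: methoxy in place of hydrogen on an aromatic carbon. Put simply, methoxy takes the place of hydrogen on an aromatic carbon of the shared core. Going by the values given here, no measured pair of compounds shows what this kind of swap does here, so any forecast must stay cautious. A single added group on an otherwise unchanged molecule gives no strong reason to predict a large shift from compound 2 at 25400 nM. The estimated step of a 1.3-fold lower number from compound 2 to compound 3 (0.10 log units; within the scatter) is small, leans slightly toward stronger inhibition and may not exceed the usual scatter. For compound 3 the expected value is 20000 nM, with an estimated range from 8000 nM to 50000 nM.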

Compound 3, half-maximal inhibitory concentration: 38100 nM
Compound 3: the middle estimate sits 1.9-fold (0.28 log units) below what was measured, and the stated range covers the measured number.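

For the compounds shown here, the new pair gives the first direct reading of this position on the shared core. In this assay, methoxy in place of hydrogen on an aromatic carbon, meta to a fused ring and para to a fused ring, gives a 1.5-fold higher number from compound 2 to compound 3 (0.18 log units; within the scatter). On this evidence, compound 2 and compound 3 cannot be told apart, so this one swap, which adds 2 heavy atoms and 1 hydrogen-bond acceptor, leaves the read-out inside the normal spread of repeated measurements. Going by these compounds alone, compound 1 differs from compound 3 in more than one place and gives a limit of the assay rather than a number, so only the pair of compound 2 and compound 3 speaks to this position: the limit of > 100000 nM in this assay, at which 1 of the 3 values shown sits.

On these data alone, whether an amine, a carboxylic acid or a longer chain such as ethoxy on this same aromatic carbon would move the number beyond the usual scatter remains open. A single pair also cannot show whether the same swap would behave alike on other aromatic carbons of the shared core.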